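The source may report more compounds than this note shows. Statements on the series, on what has been measured and on what is new or still open speak of the compounds shown alone.

Three compounds share one core and differ mainly in the chain that ends in a hydroxyl. In an assay for inhibition of Polyunsaturated fatty acid 5-lipoxygenase (Homo sapiens), read by HPLC, with stated times of 15 min and 10 min (on this read-out higher numbers stand for weaker inhibition and lower numbers for stronger inhibition), compound 1 `COC1=CC(=O)C(=O)C(CCCCCCCCCCO)=C1OC` gives 1080 nM. In this assay compound 2 `COC1=CC(=O)C(=O)C(CCCCCCCCCCCO)=C1OC` gives 1960 nM. In this assay compound 3 `COC1=CC(=O)C(OC)=C(CCCCCCCCO)C1=O` gives 1840 nM, a number that sits within the scatter of both compound 1 and compound 2, so none of the three can be set apart from the others. Within the data shown here, the only measured step that changes one place is a 1.8-fold higher number from compound 1 to compound 2 (0.26 log units; within the scatter), and it lengthens the chain by one carbon without moving the number beyond the scatter. Compound 4 `COC1=CC(=O)C(OC)=C(CCCCCCCCCCO)C1=O` is not yet measured; it differs from compound 3 by 2-hydroxyethyl in place of hydroxy on a saturated chain carbon, eight bonds along the chain from a double-bonded ring carbon, the same kind of lengthening carried one carbon further. Since compound 1 to compound 2 gave a 1.8-fold higher number from compound 1 to compound 2 (0.26 log units; within the scatter), no step beyond the scatter in this assay is expected from this change. The estimate for compound 4 is therefore 1500 nM, between 700 nM and 3500 nM, which means an expected step of a 1.2-fold lower number from compound 3 to compound 4 (0.09 log units; within the scatter).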

Compound 4, half-maximal inhibitory concentration: 1750 nM
Estimate against measurement, compound 4: 1.2-fold (0.07 log units) below; the range from low to high includes it.
By their numbers in this assay, from the lowest: compounds 1, 4, 3 and 2 (each within the scatter of the next).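

On the core of compound 3, replacing hydroxy with 2-hydroxyethyl on a saturated chain carbon, eight bonds along the chain from a double-bonded ring carbon, gives in this assay a 1.1-fold lower number from compound 3 to compound 4 (0.02 log units; within the scatter). The earlier step, a 1.8-fold higher number from compound 1 to compound 2 (0.26 log units; within the scatter), was a smaller lengthening on the core of compound 1, so the new result shows that a larger lengthening, on the core of compound 3, also stays within the scatter. Nothing available explains why this chain change leaves the number within the scatter.

The compounds shown leave open whether a longer chain would also stay within the scatter on either core. They also do not show what a carboxylic acid or an amine would do in place of the hydroxy group.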